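Compound 3 to compound 4: swap at the limit

The compounds below may be only part of what the source reports. "The series", "measured", "known", "first", "only" and "open" are said of these compounds alone.

In a functional assay on U-373MG ATCC cells for inhibition, with U373 MG (Homo sapiens) as the target, read by MTT assay, with a stated time of 7 days (on this read-out higher numbers stand for weaker inhibition of growth and lower numbers for stronger inhibition of growth), compound 3 (`Cc1cc(Cn2nnc3c(C(N)=O)ncn3c2=O)on1`) gives > 50000 nM and this is a limit, not a number. Compound 1 (`NC(=O)c1ncn2c(=O)n(Cc3ccccc3)nnc12`) gives > 50000 nM and this too is a limit. Compound 2 (`NC(=O)c1ncn2c(=O)n(Cc3cccs3)nnc12`) gives > 50000 nM as a limit as well. Among the compounds with values here, the series so far shows the limit of > 50000 nM in this assay, at which 3 of the 3 values shown sit, and no compound has a number yet.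

The change to compound 4 (`Cc1noc(Cn2nnc3c(C(N)=O)ncn3c2=O)n1`) is 3-methyl-1,2,4-oxadiazol-5-yl in place of 3-methyl-1,2-oxazol-5-yl on a saturated chain carbon bound to an aromatic nitrogen and nothing else differs. In words, 3-methyl-1,2,4-oxadiazol-5-yl takes the place of 3-methyl-1,2-oxazol-5-yl on a saturated chain carbon bound to an aromatic nitrogen.

Three measured steps change the group at this same place: a step that the two limits leave unreadable from compound 1 to compound 2 and also a step that the two limits leave unreadable from compound 1 to compound 3 and also a step that the two limits leave unreadable from compound 2 to compound 3 and none of them has a readable size. No step beyond the scatter is expected in this assay and no direction can be given, with compound 3 still at > 50000 nM as a limit. The expected step is a number no higher from compound 3 to compound 4 (the limit leaves the size open) as an estimate only. Compound 4 is expected at 50000 nM with an estimated range of 25000 nM to 100000 nM and a limit rather than a number is the likely report.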

Compound 4, concentration for 50% growth inhibition: > 50000 nM
Compound 4 gave a limit, no number; the forecaster's own chance of this, stated with the estimate: 85%; the middle value sits exactly at the limit.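

In this assay compound 4 gives > 50000 nM, which is a limit and not a number. Its steps from compound 1, compound 2 and compound 3 therefore cannot be read, and the series stands at a single limit: the limit of > 50000 nM in this assay, at which 4 of the 4 values shown sit. The compounds shown leave open whether any group on this saturated chain carbon bound to an aromatic nitrogen changes growth inhibition, and by how much.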